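Quinoline thiosemicarbazones: aryl substitution on the terminal nitrogen

This account rests on a few compounds, and the source may have more. Where it says the series, first, only, none or still open, it means among the compounds named here.

Compound 1 `S=C(N/N=C/c1ccc2ccccc2n1)Nc1cccc(Cl)c1` carries a 3-chlorophenyl group on the thiosemicarbazone nitrogen. In a functional assay on HL-60 cells (Homo sapiens) for antiproliferative activity, read by sulforhodamine B assay, with a stated time of 72 h (a lower number here means a stronger inhibitor, a higher number a weaker inhibitor), compound 1 gives 28800 nM, the higher of the two numbers obtained; compound 2 `CN(C)C(=S)N/N=C/c1ccc2ccccc2n1`, with two methyl groups on that nitrogen, gives 50 nM, and the gap between them lies well beyond the scatter. Compound 3 `NC(=S)N/N=C/c1cc2cccnc2s1`, on a different core, reaches only the limit > 100000 nM in this assay, as noted in the limit of > 100000 nM in this assay, at which 1 of the 3 values shown sits.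

Compound 4 `COc1ccc(NC(=S)N/N=C/c2ccc3ccccc3n2)cc1` is not yet measured. It differs from compound 1 by 4-methoxyphenyl in place of 3-chlorophenyl on an amide-type nitrogen. Within the data shown here, no measured step of this kind exists in the set, so the expected step of a 1.2-fold lower number from compound 1 to compound 4 (0.06 log units; within the scatter) is small, in either direction, and not clearly beyond the scatter. Compound 4 is estimated at 25000 nM, within 4000 nM to 100000 nM.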

Compound 4, half-maximal inhibitory concentration: 43800 nM
Compound 4: the middle estimate sits 1.8-fold (0.24 log units) below what was measured; the measured number falls inside the stated range.
By their numbers in this assay, from the lowest: compound 2; then compounds 1 and 4 (each within the scatter of the next). At a limit, above all of these: compound 3.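

In this assay the swap to 4-methoxyphenyl in place of 3-chlorophenyl on the amide-type nitrogen gives a 1.5-fold higher number from compound 1 to compound 4 (0.18 log units; within the scatter) and so leaves the two aryl groups indistinguishable at this position. The number seen for compound 1 is therefore not particular to 3-chlorophenyl, since a second substituted phenyl group reads alike. No measured property in hand bears on this step.

Still open, from the compounds shown here alone, is how this nitrogen would read with an unsubstituted phenyl or a single methyl group, or with a phenyl ring carrying an amine or a carboxylic acid.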